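Bis-thioether dicarboxylates: chain replacement at the aryl ether

The source may report more compounds than this note shows. Statements on the series, on what has been measured and on what is new or still open speak of the compounds shown alone.

Three members of the series carry a common core with two thiopropanoic acid arms and differ only in the side chain on the aromatic ring. Compound 1 `CCCCCCCCCCC#Cc1ccccc1C(SCCC(=O)O)SCCC(=O)O` bears an alkyne-linked chain, compound 2 `CCCCc1ccc(CCCCc2ccccc2C(SCCC(=O)O)SCCC(=O)O)cc1` a butyl-phenyl-butyl chain, and compound 3 `CCCCCCCCCOc1ccccc1C(SCCC(=O)O)SCCC(=O)O` a nonyloxy chain. In an assay on membranes from lung (Cavia porcellus) for binding affinity to cysteinyl leukotriene receptor (Homo sapiens) (on this read-out lower numbers stand for stronger inhibition and higher numbers for weaker inhibition), compound 1 gives 2520 nM, compound 2 gives 4230 nM, and compound 3 gives 4090 nM. Compound 3 sits next to compound 2 on these numbers and somewhat apart from compound 1, yet both of those gaps fall within the usual scatter, so the three side chains cannot be told apart on this read-out.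

Compound 4 `CCOCCOCCOCCOc1ccccc1C(SCCC(=O)O)SCCC(=O)O` has not been measured. It differs from compound 3 in one place: 2-(2-ethoxyethoxy)ethoxy in place of heptyl on a saturated chain carbon, two bonds along the chain from an oxygen on an aromatic ring. Within the data shown here, no pair of measured compounds shows a change of this kind, so the direction of the step is not anchored by the data; the three measured chains, all hydrocarbon, give indistinguishable numbers, and a chain carrying three ether oxygens is a departure from that set. The expected step from compound 3 to compound 4 is a 1.6-fold higher number from compound 3 to compound 4 (0.20 log units; within the scatter), a modest weakening that may well lie within the scatter. Compound 4 is thus expected to give 6500 nM, with a plausible range from 2500 nM to 17000 nM.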

Compound 4, inhibition constant: > 20000 nM
Compound 4: no number, only a limit (the forecaster's own chance of this, stated with the estimate: 10%); middle value at least 3.0-fold (0.48 log units) from the limit.
By their numbers in this assay, from the lowest: compounds 1, 3 and 2 (each within the scatter of the next). At a limit, above all of these: compound 4.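

The reading for compound 4 is a limit of the assay and not a number: the limit of > 20000 nM in this assay, at which 1 of the 4 values shown sits.

This position is not indifferent to the make-up of the chain. In this assay, among these compounds, compounds 1, 2 and 3 could not be told apart despite their different hydrocarbon side chains, whereas 2-(2-ethoxyethoxy)ethoxy in place of heptyl on a saturated chain carbon, two bonds along the chain from an oxygen on an aromatic ring, gives an at least 4.8-fold higher number from compound 3 to compound 4 (0.68 log units; beyond the scatter), the first change in this set that lies beyond the scatter. Going by these compounds, this step fixes only a lower bound, so the full size of the loss remains unknown.

Open, on these data alone, is whether the loss follows the ether oxygens as such, their number or their spacing, and a single pair cannot separate these readings. A chain with just one ether oxygen, or one carrying a hydroxyl or an amine, would help to show whether any heteroatom in the chain is tolerated, and a longer all-carbon chain would show how far the hydrocarbon set extends.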